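This account rests on a few compounds, and the source may have more. Where it says the series, first, only, none or still open, it means among the compounds named here.

Measured so far:
compound 1, `Cc1cc(C)cc(NC(=O)COc2cc(C)nc3ccc(F)cc23)c1`, 5.79 in a physicochemical assay for lipophilicity, read by HPLC, in phosphate buffer, measured as chromatographic lipophilicity, at pH 7.4; on this read-out higher numbers stand for higher lipophilicity and lower numbers for lower lipophilicity
compound 2, `COc1ccc2nc(C)cc(OCC(=O)Nc3c(C)cccc3C)c2c1`, 4.55 in this assay

Of the two numbers, compound 2 stands lower; compound 1 gives the higher value, and the gap between them lies beyond the usual scatter of this assay. Compound 3, `COc1ccc2nc(C)cc(OCC(=O)Nc3nc(C)c(C)s3)c2c1`, has not been measured yet. It differs from compound 2 in one place: 4,5-dimethyl-1,3-thiazol-2-yl in place of 2,6-dimethylphenyl on an amide-type nitrogen. For the measured compounds named here, no measured pair shows this kind of change, so its effect has to be estimated rather than read off. For compound 3 a downward step is expected, a number 0.70 log units lower from compound 2 to compound 3 (beyond the scatter), larger than the scatter but smaller than the distance that separates compound 2 from compound 1. Compound 3 is therefore expected to give about 3.85 in this assay, with a likely range from 3.3 to 4.4.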

Compound 3, distribution coefficient: 4.24
Compound 3: middle estimate off by 0.39 log units, on the low side, within the range that was stated.
By their numbers in this assay, from the lowest: compound 3; then compound 2; then compound 1.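

For the compounds shown here, this pair gives the first direct reading of a change on the amide-type nitrogen: in this assay, putting 4,5-dimethyl-1,3-thiazol-2-yl in place of 2,6-dimethylphenyl gives a number 0.31 log units lower from compound 2 to compound 3 (beyond the scatter). The swap replaces a six-membered aromatic ring of carbon only with a five-membered aromatic ring with 2 hetero atoms, yet the number moves only modestly, and this holds for this one pair alone. Nothing available explains why the step has this size.

Open, going by these compounds, is whether the two methyl groups or the ring itself account for the step, which a plain 1,3-thiazol-2-yl on the same nitrogen could help separate. A pyridin-2-yl group there, or the same swap on the core of compound 1, would show whether the step carries over.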